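A few compounds are considered here, and "the series" means these few. Any claim that something is new, unique, unknown or untested is made for them only; others in the source may bear on it.

Compound 1 `COc1cc(NC(C)CCCNC(=O)NNC(=O)Nc2cc(C(F)(F)F)cc(C(F)(F)F)c2)c2ncccc2c1`: 22000 nM
Compound 2 `COc1cc(NC(C)CCCNC(=O)NNC(=O)Nc2cccc(Cl)c2)c2ncccc2c1`: 93000 nM
Compound 3 `COc1cc(NC(C)CCCNC(=O)NNC(=O)Nc2ccc(C(F)(F)F)cc2)c2ncccc2c1`: 24000 nM

In a functional assay on MOLT-4 cells (Homo sapiens) for inhibition, read by MTT assay, with a stated time of 72 h (on this read-out lower numbers stand for stronger inhibition and higher numbers for weaker inhibition), compound 2 gives the highest of the three numbers, with compound 3 nearest and compound 1 furthest, both beyond the scatter. Compound 4 `COc1cc(NC(C)CCCNC(=O)Nc2ccc(Cl)cc2)c2ncccc2c1` is derived from compound 2 by the change (4-chlorophenyl in place of ((3-chlorophenyl)carbamoyl)amino on an amide-type nitrogen). For the measured compounds named here, no measured step covers this change directly. Going by the values given here, the only step available, a 3.9-fold lower number from compound 2 to compound 3 (0.59 log units; beyond the scatter), alters the aryl group while the rest of the structure is retained, and compounds 1 and 3 show that varied aryl groups give numbers within a modest span of each other. On this basis the expected step is a 2.7-fold lower number from compound 2 to compound 4 (0.42 log units; beyond the scatter), of uncertain direction and possibly within the scatter. Compound 4 is estimated at 35000 nM, with a range from 9000 nM to 140000 nM.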

Compound 4, half-maximal inhibitory concentration: 24000 nM
For compound 4 the middle estimate is 1.5-fold (0.16 log units) above the measured one, and the stated range covers the measured number.
By their numbers in this assay, from the lowest: compounds 1, 3 and 4 (each within the scatter of the next); then compound 2.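

In this assay there is a 3.9-fold lower number from compound 2 to compound 4 (0.59 log units; beyond the scatter) when 4-chlorophenyl replaces ((3-chlorophenyl)carbamoyl)amino on the amide-type nitrogen. The earlier compounds shown here varied only the aryl group, whereas this change shows that the carbamoyl-amino unit, with its hydrogen-bond donors, can be absent at this position without the number rising. No data shown here account for this step.

The step removes that unit and changes the chlorophenyl group together, so the two contributions remain unseparated. Also open, going by these compounds, is how an amine or a carboxylic acid on this nitrogen would read out.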